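This account rests on a few compounds, and the source may have more. Where it says the series, first, only, none or still open, it means among the compounds named here.

Of the compounds shown here, two that share one core have been tested so far in a functional assay on A549 cells (Homo sapiens) for cytotoxicity, read by MTT assay, with a stated time of 48 h; a lower number here means a stronger inhibitor, a higher number a weaker inhibitor. Compound 1 `COc1cccc(OC)c1/C=C/[C@](C)(O)CC[C@@H]1[C@@]2(C)CCCC(C)(C)[C@@H]2CC[C@@]1(C)O` gives 42000 nM, while compound 2 `Cc1cccc(C)c1/C=C/[C@](C)(O)CC[C@@H]1[C@@]2(C)CCCC(C)(C)[C@@H]2CC[C@@]1(C)O` gives 3340 nM, the lower of the two numbers and so the stronger inhibitor of the pair. The next compound, compound 3 `CC1(C)CCC[C@]2(C)[C@@H](CC[C@@](C)(O)/C=C/c3ccc(F)cc3)[C@](C)(O)CC[C@@H]12`, keeps the core and changes only the aromatic group on the double-bonded chain: 4-fluorophenyl in place of 2,6-dimethylphenyl on a double-bonded chain carbon bound to a double-bonded chain carbon. Within the data shown here, the one measured step at this place is a 13-fold lower number from compound 1 to compound 2 (1.10 log units; beyond the scatter), a large change that came with 2,6-dimethylphenyl in place of 2,6-dimethoxyphenyl. Among the measured compounds shown here, it shows that the read-out can respond strongly to the group at this place, but no compound carrying 4-fluorophenyl has yet been measured, so the direction remains uncertain. For the measured compounds named here, with only two values to go on, a moderate move toward a higher number is expected, since compound 2 at 3340 nM is the lower of them, and a wide range is needed. The expected change is a 2.4-fold higher number from compound 2 to compound 3 (0.38 log units; beyond the scatter). Compound 3 is estimated at 8000 nM, with an expected range from 2500 nM to 28000 nM.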

Compound 3, half-maximal inhibitory concentration: 3100 nM
Beside the measured number, compound 3's estimate is 2.6-fold (0.41 log units) above it; the range from low to high includes it.
By their numbers in this assay, from the lowest: compounds 3 and 2 (each within the scatter of the next); then compound 1.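

In this assay, putting 4-fluorophenyl in place of 2,6-dimethylphenyl on a double-bonded chain carbon gives a 1.1-fold lower number from compound 2 to compound 3 (0.03 log units; within the scatter), so these two aromatic groups cannot be told apart here, although one carries two methyl groups and the other a single fluorine. The large gap seen earlier now appears with a second partner, a 14-fold lower number from compound 1 to compound 3 (1.13 log units; beyond the scatter), which means that compound 1, with its 2,6-dimethoxyphenyl group, is the one that stands apart among the three, and that the number near compound 2 is not tied to the two methyl groups alone. No measurement is available here that explains why these groups give these numbers.

The compounds shown leave open whether the weaker result for compound 1 follows from having methoxy groups at all or from having two of them in that arrangement, which a phenyl ring with a single methoxy group could help to settle. They also leave open how far this tolerance extends, for instance to a plain phenyl ring or to a phenyl ring carrying an amine or a carboxylic acid.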